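This account rests on a few compounds, and the source may have more. Where it says the series, first, only, none or still open, it means among the compounds named here.

Compound 3 (`COC(=O)N(C)CC#CCn1ccnc1`) reads > 100 mg/kg in a functional assay on the whole organism for antagonist activity, with Mus musculus as the target (a higher number here means that more compound is needed for the effect, a lower number that less compound is needed), which is a limit of the assay and not a number. Compound 1 (`CC(=O)N(C)CC#CCn1cncc1C`) reads > 100 mg/kg, also a limit. Compound 2 (`COC(=O)NCC#CCn1cncc1C`) gives 80 mg/kg. The data therefore cluster at the limit of > 100 mg/kg in this assay, at which 2 of the 3 values shown sit.

Compound 4 (`COC(=O)N(C)CC#CCn1cncc1C`) follows from compound 3 by methyl in place of hydrogen on an aromatic carbon. Among the compounds with values here, no measured step makes this change. Within the data shown here, the only step available, an at least 1.2-fold lower number from compound 1 to compound 2 (0.09 log units; that floor lies within the scatter), concerns the other end of the molecule and bears on it only indirectly, though compound 1 and compound 2 both carry this methyl. No step beyond the scatter can be firmly expected in this assay, and the estimated step is a number no higher from compound 3 to compound 4 (the limit leaves the size open). The expected value for compound 4 is 100 mg/kg, with an estimated range of 45 mg/kg to 200 mg/kg.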

Compound 4, dose for half-maximal effect: 5.4 mg/kg
For compound 4 the middle estimate is 19-fold (1.27 log units) above the measured one; the whole stated range lies above it.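

In this assay the methyl on an aromatic carbon, next to the ring atom that bears a large group, has a large effect: an at least 18-fold lower number from compound 3 to compound 4 (1.26 log units; beyond the scatter). It does not act alone: the methyl on the amide-type nitrogen gives a 15-fold lower number from compound 2 to compound 4 (1.17 log units; beyond the scatter), and methoxy in place of methyl on the carbonyl carbon gives an at least 18-fold lower number from compound 1 to compound 4 (1.26 log units; beyond the scatter). Going by these compounds, two of these steps start from a limit of the assay, so their full size stays open: the limit of > 100 mg/kg in this assay, at which 2 of the 4 values shown sit.

On these data alone, whether ethyl or chloro on this ring carbon keeps the number low remains open. So does the effect of a longer chain on the amide-type nitrogen.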